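A few compounds are considered here, and "the series" means these few. Any claim that something is new, unique, unknown or untested is made for them only; others in the source may bear on it.

Working notes on a series of nucleoside analogues sharing one core, tested in a functional assay on Vero cells (Chlorocebus sabaeus) for inhibition; a higher number here means a weaker inhibitor, a lower number a stronger inhibitor. Compound 1 `OC[C@H]1O[C@H](n2cnc3c(O)ncnc32)CS1` is recorded only as a limit of this assay, > 100000 nM. Compound 2 `OC[C@H]1O[C@@H](n2cnc3c(Cl)ncnc32)CS1` gives 46500 nM in this assay. Compound 3 `Nc1nc(Cl)c2ncn([C@@H]3CS[C@@H](CO)O3)c2n1` is likewise recorded only as a limit, > 100000 nM. Going by the values given here, two of the three values so far sit at that limit (the limit of > 100000 nM in this assay, at which 2 of the 3 values shown sit). Compound 4 `Nc1nc(O)c2ncn([C@@H]3CS[C@@H](CO)O3)c2n1` is not yet measured; it differs from compound 3 by hydroxy in place of chloro on an aromatic carbon. Among the compounds with values here, no measured step between compounds differing in one place exists, so the size of this step is a matter of expectation. Compound 1, which carries the hydroxy, is itself a limit value, > 100000 nM. Compound 4 is therefore expected to stay at the limit, with an expected step that the limit leaves unreadable from compound 3 to compound 4. The estimate for compound 4 is 200000 nM, between 100000 nM and 1000000 nM.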

Compound 4, half-maximal inhibitory concentration: 63600 nM
Compound 4: middle estimate off by 3.1-fold (0.50 log units), on the high side; the whole stated range lies above it.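

In this assay, compound 4 gives a readable number with hydroxy on this aromatic carbon, which compound 1, also a hydroxy compound but without the amino group, did not show. Hydroxy in place of chloro gives an at least 1.5-fold lower number from compound 3 to compound 4 (0.19 log units; that floor lies within the scatter), and amino in place of hydrogen gives an at least 1.5-fold lower number from compound 1 to compound 4 (0.19 log units; that floor lies within the scatter). Both steps are only floors, as each starts from a limit: the limit of > 100000 nM in this assay, at which 2 of the 4 values shown sit.

Going by these compounds, the true size of both steps remains open. So does how an amine or a methoxy group on this aromatic carbon would compare with chloro and hydroxy.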